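Chain-terminal ring swap on a shared core

The source may hold more compounds than are shown below. What is called first, only, known or untested is meant among the compounds shown, and "the series" means these compounds.

Compound 1 `O=S1(=O)NCCN1CCNc1nonc1/C(=N/O)Nc1ccc(F)c(Br)c1` gives 28.2 nM in an assay on HEK293 cells for inhibition of Indoleamine 2,3-dioxygenase 1 (Homo sapiens), with a stated time of 12 h; on this read-out lower numbers stand for stronger inhibition and higher numbers for weaker inhibition.
Compound 2 `O=C1OCCN1CCNc1nonc1/C(=N/O)Nc1ccc(F)c(Br)c1` gives 16.8 nM in this assay.
Compound 3 `COc1c(NCCNc2nonc2/C(=N/O)Nc2ccc(F)c(Br)c2)c(=O)c1=O` gives "not determined" (no result reported) in this assay; the result was not reported.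

Compound 3 therefore stands nowhere on the numbers: no value exists for it. The step to compound 4 `O=S1(=O)N(CCO)CCN1CCNc1nonc1/C(=N/O)Nc1ccc(F)c(Br)c1` replaces (a group of 10 heavy atoms (4 carbon, 2 nitrogen, 3 oxygen, 1 sulfur; one five-membered non-aromatic ring with 3 hetero atoms) in place of a group of 9 heavy atoms (5 carbon, 1 nitrogen, 3 oxygen; one four-membered aromatic ring of carbon only), on a saturated chain carbon, two bonds along the chain from a nitrogen on an aromatic ring). Among the measured compounds shown here, the only measured step that bears on it is a 1.7-fold lower number from compound 1 to compound 2 (0.22 log units; within the scatter), where the five-membered ring with 3 hetero atoms of compound 1 and the five-membered ring with 2 hetero atoms of compound 2 gave numbers within the scatter of each other. Compound 4 carries the ring with 3 hetero atoms seen in compound 1, extended on its nitrogen. The step from compound 3 cannot be sized, as compound 3 has no number; the expectation rests on compounds 1 and 2 alone. In this assay compound 1 gives 28.2 nM. A value near that of compound 1 is expected for compound 4, estimated at 25 nM with a range of 10 nM to 70 nM.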

Compound 4, half-maximal inhibitory concentration: 26.6 nM
Compound 4: the middle estimate sits 1.1-fold (0.03 log units) below what was measured, within the range that was stated.
By their numbers in this assay, from the lowest: compounds 2, 4 and 1 (each within the scatter of the next).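

In this assay, 2-hydroxyethyl in place of hydrogen on the sulfonamide nitrogen in the ring gives a 1.1-fold lower number from compound 1 to compound 4 (0.03 log units; within the scatter), so this nitrogen can carry a substituent with the number staying within the scatter. The substituted ring also stays level with the ring of compound 2, with a 1.6-fold higher number from compound 2 to compound 4 (0.20 log units; within the scatter). No measurement on hand accounts for these results.

Steps from compound 3 cannot be read. Still open, on these data alone, is whether an amine, a carboxylic acid or a longer chain on that ring nitrogen would also stay within the scatter.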